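Chloro for ethyl on the pyridine-bearing thiazole series

The compounds below may be only part of what the source reports. "The series", "measured", "known", "first", "only" and "open" are said of these compounds alone.

Measured compounds:
compound 1 `C#Cc1cnccc1-c1csc(Nc2cccc(C)c2)n1`: 1380 nM
compound 2 `CCc1cnccc1-c1csc(Nc2cccc(C)c2)n1`: 6310 nM
compound 3 `Cc1cccc(Nc2nc(-c3ccncc3-c3ccccc3)cs2)c1`: 11600 nM; 11700 nM (2 entries)

All three share one core and were tested in a functional assay on RCC4 cells (Homo sapiens) for inhibition, read by XTT assay, with a stated time of 4 days; a lower number here means a stronger inhibitor, a higher number a weaker inhibitor. Compound 1 gives 1380 nM and compound 2 gives 6310 nM, the higher of the two single numbers; compound 3 has several entries the several entries of compound 3 in this assay, 11600 nM; 11700 nM (2 entries) and so stands apart from that comparison. Going by the values given here, the only measured step that changes the same position is a 4.6-fold higher number from compound 1 to compound 2 (0.66 log units; beyond the scatter), a modest move toward weaker inhibition when ethyl replaces ethynyl.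

The step to compound 4 `Cc1cccc(Nc2nc(-c3ccncc3Cl)cs2)c1` is chloro in place of ethyl on an aromatic carbon, on an aromatic carbon of a six-membered aromatic ring with one nitrogen, ortho to a large group and two atoms from the ring nitrogen. Replacing the two-carbon chain with a single chlorine removes bulk at the place where compound 1 and compound 2 differ; since that prior step was only modest, compound 4 is expected to land near compound 2, with at most a modest change and no confident direction beyond the scatter. The expected step is a 1.6-fold lower number from compound 2 to compound 4 (0.20 log units; within the scatter). Compound 4 is therefore estimated at 4000 nM, in a range from 1500 nM to 12000 nM.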

Compound 4, half-maximal inhibitory concentration: 2950 nM
Estimate against measurement, compound 4: 1.4-fold (0.13 log units) above; low and high end bracket the measured number.
By their numbers in this assay, from the lowest: compound 1; then compound 4; then compound 2.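

In this assay, this position takes a single chlorine in place of the ethyl chain with a small gain rather than a loss: a 2.1-fold lower number from compound 2 to compound 4 (0.33 log units; beyond the scatter). Chloro does not match ethynyl, however, with a 2.1-fold higher number from compound 1 to compound 4 (0.33 log units; beyond the scatter), so the three groups now fall in the order ethynyl, chloro, ethyl, from the lowest number to the highest. Phenyl in the same place gives numbers above that of compound 4, as its entries show: the several entries of compound 3 in this assay, 11600 nM; 11700 nM (2 entries)

The compounds shown leave open whether a fluorine, a methoxy group or an amine at this position would give a number nearer that of ethynyl or that of ethyl. They also do not tell why chloro and ethynyl both give lower numbers than ethyl.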